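Swapping Benzyl for Methoxyphenyl: an Expected Small Step

A few compounds are considered here, and "the series" means these few. Any claim that something is new, unique, unknown or untested is made for them only; others in the source may bear on it.

Of the compounds shown here, two have been measured in an assay for binding affinity to Alpha-1B adrenergic receptor (Homo sapiens); a lower number here means a stronger inhibitor, a higher number a weaker inhibitor. Compound 1 `O=c1c2ccccc2c(Cc2ccc(Cl)cc2)nn1C1CCCN(Cc2ccc(OCCCN3CCCCCC3)cc2)CC1` gives 126 nM in this assay. Compound 2 `CN1CCC[C@@H]1Cn1nc(CCc2ccccc2)c2ccccc2c1=O` gives 200 nM in this assay, the higher of the two numbers, though its gap to compound 1 lies within the scatter of repeated measurements, so the two cannot be ranked against each other.

Compound 3 `COc1ccc(Cc2nn(C[C@H]3CCCN3C)c(=O)c3ccccc23)cc1` has not yet been measured. It differs from compound 2 in one place: 4-methoxyphenyl in place of benzyl on a saturated chain carbon bound to an aromatic carbon. Among the measured compounds shown here, no measured pair in this set shows what such a change does, so the expectation rests on compound 2 alone. Compound 3 is expected to stay close to compound 2, with the step from a 1.1-fold lower number from compound 2 to compound 3 (0.05 log units; within the scatter) not expected to reach beyond the scatter in either direction. Compound 3 is estimated at 180 nM in this assay, with a range from 60 nM to 550 nM.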

Compound 3, inhibition constant: 158 nM
Beside the measured number, compound 3's estimate is 1.1-fold (0.06 log units) above it; the measured number falls inside the stated range.
By their numbers in this assay, from the lowest: compounds 1, 3 and 2 (each within the scatter of the next).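

In this assay, putting 4-methoxyphenyl in place of benzyl on a saturated chain carbon bound to an aromatic carbon gives a 1.3-fold lower number from compound 2 to compound 3 (0.10 log units; within the scatter) and provides the only reading of a change at this position among the compounds shown. This position therefore accepts the exchange of benzyl for 4-methoxyphenyl, which brings one hydrogen-bond acceptor, without a step beyond the scatter, so compound 2 and compound 3 cannot be ranked against each other. No measurement available here speaks to why these two compounds read alike.

From the compounds shown here alone, it remains open whether a carboxylic acid or an amine in place of the methoxy group, or a longer chain at this carbon, would give a step beyond the scatter. Compound 1 differs from compound 3 in more than one place, so it cannot answer this question.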